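This account rests on a few compounds, and the source may have more. Where it says the series, first, only, none or still open, it means among the compounds named here.

Series notes. In a functional assay on HCT-116 cells (Homo sapiens) for inhibition, read by MTT assay, with a stated time of 96 h (on this read-out higher numbers stand for weaker inhibition of growth and lower numbers for stronger inhibition of growth), compound 1 `O=C(OCc1ccccc1)SCCCCCCNC(=O)c1cc(-c2ccncc2)n[nH]1` gives 18200 nM and compound 2 `C=CCOC(=O)SCCCCCCNC(=O)c1cc(-c2ccncc2)n[nH]1` gives 32900 nM, a pair separated by a 1.8-fold higher number from compound 1 to compound 2 (0.26 log units; within the scatter). Compound 3 `CCC(=O)SCCCCCCNC(=O)c1cc(-c2ccncc2)n[nH]1` reaches only the assay limit, > 50000 nM, which is a limit and not a number. Compound 3 therefore stands at the edge of the numbers shown: the moves onto it are an at least 2.7-fold higher number from compound 1 to compound 3 (0.43 log units; beyond the scatter) and an at least 1.5-fold higher number from compound 2 to compound 3 (0.18 log units; that floor lies within the scatter). Compound 4 `CSCCCCCCNC(=O)c1cc(-c2ccncc2)n[nH]1` differs from compound 3 by methyl in place of propanoyl on a sulfur. Among the measured compounds shown here, both measured steps onto compound 3 swapped a group on a carbonyl carbon; no measured step removes the carbonyl itself, so the new change has no close precedent, and the limit of > 50000 nM in this assay, at which 1 of the 3 values shown sits, bounds what those steps can show. The expected step is a step that the limit leaves unreadable from compound 3 to compound 4. Compound 4 is expected near 80000 nM, within 30000 nM to 250000 nM.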

Compound 4, concentration for 50% growth inhibition: > 50000 nM
Compound 4 ended at the assay's limit; the forecaster's own chance of this, stated with the estimate: 80%; the middle value is on the limit's open side.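

In this assay, a sulfur carrying methyl, with no carbonyl on it, now sits at the limit alongside propanoyl, so the step between compound 3 and compound 4 cannot be read: the limit of > 50000 nM in this assay, at which 2 of the 4 values shown sit.

Methyl in place of benzyloxycarbonyl on the sulfur gives an at least 2.7-fold higher number from compound 1 to compound 4 (0.43 log units; beyond the scatter), and methyl in place of allyloxycarbonyl gives an at least 1.5-fold higher number from compound 2 to compound 4 (0.18 log units; that floor lies within the scatter).

On these data alone, whether compound 3 and compound 4 differ at all remains open, as does the outcome with a free thiol, an amine or a longer chain on this sulfur.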